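The source may hold more compounds than are shown below. What is called first, only, known or untested is meant among the compounds shown, and "the series" means these compounds.

Compound 1 `CC(=N)NCC1CCCc2cc(S(=O)(=O)c3ccccc3)ccc21` gives 0.631 nM in an assay on isolated protein for displacement of a labelled ligand from 5-hydroxytryptamine receptor 6 (Homo sapiens) (on this read-out lower numbers stand for stronger inhibition and higher numbers for weaker inhibition), and compound 2 `CNCC1CCCc2cc(S(=O)(=O)c3ccccc3)ccc21` gives 0.316 nM in this assay. Going by the values given here, the only one-place step among the measured compounds, a 2.0-fold lower number from compound 1 to compound 2 (0.30 log units; within the scatter), sits on an amine nitrogen. Compound 3 `O=C(NC[C@@H]1CCCc2cc(S(=O)(=O)c3cccc(F)c3)ccc21)c1ccc[nH]1`, which carries a fluorine on its shared core and a carbonyl-linked amide, gives 5.01 nM in this assay, the highest of the three numbers and beyond the scatter from both compound 1 and compound 2.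

Compound 4 `NC(=O)NC[C@@H]1CCCc2cc(S(=O)(=O)c3cccc(F)c3)ccc21` keeps the core of compound 3 and changes only the group on the carbonyl carbon: amino in place of 1H-pyrrol-2-yl on a carbonyl carbon. Among the compounds with values here, no measured step touches this carbonyl carbon; the one step known, on the amine nitrogen, lies within the scatter and so gives neither a direction nor a size for a change at an amide carbonyl. With nothing to carry over, the step of a 1.6-fold higher number from compound 3 to compound 4 (0.20 log units; within the scatter) is expected to stay within the scatter or to go slightly toward higher numbers, and compound 4 is estimated at 8 nM, in the range 2 nM to 32 nM.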

Compound 4, inhibition constant: 0.2 nM
Compound 4: the middle estimate sits 40-fold (1.60 log units) above what was measured; the whole stated range lies above it.
By their numbers in this assay, from the lowest: compounds 4, 2 and 1 (each within the scatter of the next, the first and the last beyond it); then compound 3.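

Going by these compounds alone, on a carbonyl carbon whose other neighbour is an amide-type nitrogen, the choice of group carries a large effect in this assay: the change to amino gives a 25-fold lower number from compound 3 to compound 4 (1.40 log units; beyond the scatter) and is the first one-place step beyond the scatter, whereas a 2.0-fold lower number from compound 1 to compound 2 (0.30 log units; within the scatter) on the amine nitrogen stays within it. Read one bond further out, ((1H-pyrrol-2-yl)carbonyl)amino becomes ureido, so a five-membered aromatic ring leaves and a single nitrogen enters. The counts of hydrogen-bond donors and acceptors are equal for the two groups, so those counts do not follow this step.

Open, as far as these compounds go, is whether a methyl, a phenyl or a dimethylamino group on this carbonyl carbon would fall with amino or with 1H-pyrrol-2-yl. Also open, from the compounds shown here alone, is whether the same change gives a step of this size on a core without the fluorine. Nothing given here explains the size of the step.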